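This account rests on a few compounds, and the source may have more. Where it says the series, first, only, none or still open, it means among the compounds named here.

Compound 1 `CCC(=O)Nc1ncc(-c2ccc(OC)cc2)n1C` is the simplest member of this small set. In a toxicity assay on THP-1 cells (Homo sapiens) for inhibition (on this read-out higher numbers stand for lower toxicity in this test and lower numbers for higher toxicity in this test), compound 1 gives > 100000 nM, which is a limit of the assay rather than a number. Compound 2 `COc1ccc(-c2cnc(NC(=O)c3ccco3)n2C)cc1` likewise gives > 100000 nM in this assay, again only a limit. The step that the two limits leave unreadable from compound 1 to compound 2 cannot be sized because the limit of > 100000 nM in this assay, at which 2 of the 3 values shown sit, leaves both ends open. Compound 3 `O=C(Nc1ncc(-c2ccccc2)o1)c1ccc(F)cc1` differs from compound 2 in several places. In this assay compound 3 gives 17000 nM, a real number showing that measurable toxicity does occur within this series. Compound 4 `COc1ccc(-c2cnc(NC(=O)c3cccc(Cl)c3)n2C)cc1` has not yet been measured; its change from compound 2 is 3-chlorophenyl in place of furan-2-yl on a carbonyl carbon. For the measured compounds named here, no measured step bears directly on this change, and the only readable comparison, compound 3 against the limits of compounds 1 and 2, involves other differences as well. Compound 4 is therefore expected to remain weakly toxic, with an estimated value of 60000 nM and a range from 20000 nM to 150000 nM in this assay. The implied step an at least 1.6-fold lower number from compound 2 to compound 4 (0.22 log units; that floor lies within the scatter) is an expectation, not a measurement, and may again end at a limit.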

Compound 4, half-maximal cytotoxic concentration: > 28000 nM
Compound 4 ended at the assay's limit; the forecaster's own chance of this, stated with the estimate: 40%; the middle value lies beyond the limit too.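

In this assay compound 4 gives > 28000 nM, which is a limit and not a number. Compound 1 and compound 2 also stand only at limits, and neither step to compound 4 can be read. The compounds shown leave open whether 3-chlorophenyl in place of furan-2-yl on a carbonyl carbon changes toxicity at all.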